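Nitro to methyl exchange carried across two cores

The source may report more compounds than this note shows. Statements on the series, on what has been measured and on what is new or still open speak of the compounds shown alone.

Compound 1 `O=C1NN(c2ccc([N+](=O)[O-])cc2)C(=O)C2(CSC3=C2C(=O)c2ncccc2C3=O)N1` and compound 2 `Cc1ccc(N2NC(=O)NC3(CSC4=C3C(=O)c3ncccc3C4=O)C2=O)cc1` share one core; compound 3 `O=C1C2=C(C(=O)c3ncccc31)C1(CS2)NC(=O)N(c2ccc([N+](=O)[O-])cc2)C1=O` carries the same nitrophenyl group on a second core, and compound 4 `Cc1ccc(N2C(=O)NC3(CSC4=C3C(=O)c3ncccc3C4=O)C2=O)cc1` is its methyl counterpart. In a functional assay on ACHN cells (Homo sapiens) for antiproliferative activity, read by MTT assay, with a stated time of 96 h (a lower number here means a stronger inhibitor, a higher number a weaker inhibitor), compound 1 gives 650 nM, and compound 2 gives 500 nM. The step of a 1.3-fold lower number from compound 1 to compound 2 (0.11 log units; within the scatter) belongs to the change (methyl in place of nitro on an aromatic carbon). Compound 3 gives 100 nM; the difference between the two cores is not broken down here, but the numbers show compound 3 lying below compound 1 and compound 2 by more than the scatter. Compound 4 differs from compound 3 by methyl in place of nitro on an aromatic carbon, the same change as seen between the first two compounds, at the same kind of place on an aromatic carbon, para to a large group. The expectation for compound 4 rests on the measured step of a 1.3-fold lower number from compound 1 to compound 2 (0.11 log units; within the scatter), which stayed within the scatter; the step of a 1.3-fold lower number from compound 3 to compound 4 (0.10 log units; within the scatter) is expected to be of similar size. Compound 4 is therefore estimated at 80 nM, with a likely range from 35 nM to 180 nM.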

Compound 4, half-maximal inhibitory concentration: 12 nM
The estimate for compound 4 lay 6.7-fold (0.82 log units) above the measured number; measured number below the stated range.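

In this assay, the exchange of 4-nitrophenyl for 4-methylphenyl gives an 8.3-fold lower number from compound 3 to compound 4 (0.92 log units; beyond the scatter), a step that does not match the one seen for the same exchange on the core of compound 1. For the compounds shown here, in these two pairs the size of the step depends on the core, so a step read on one core cannot simply be carried over to the other: the same change on two cores in this assay, a 1.3-fold lower number (0.11 log units; within the scatter) from compound 1 to compound 2 and an 8.3-fold lower number (0.92 log units; beyond the scatter) from compound 3 to compound 4, 6.4-fold (0.81 log units) apart, beyond the scatter of two such steps This rests on only two matched pairs and a single exchange, so it gives no general rule for the series and does not show why the two cores respond differently.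

From the compounds shown here alone, it remains open whether this dependence on the core also holds for other groups at the same aromatic carbon, para to a large group, such as an amine or a carboxylic acid. Also open, going by these compounds, is whether a longer chain in place of the methyl would follow the step seen on the core of compound 3 or the one seen on the core of compound 1.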